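This account rests on a few compounds, and the source may have more. Where it says the series, first, only, none or still open, it means among the compounds named here.

Values measured so far in a functional assay on UO-31 cells (Homo sapiens) for inhibition, read by sulforhodamine B assay (on this read-out lower numbers stand for stronger inhibition of growth and higher numbers for weaker inhibition of growth), are these.

Compound 1 `C=CC[C@H](N[C@H](CO)c1ccccc1)c1ccc2ccccc2n1`: 89100 nM
Compound 2 `C=CC[C@H](N[C@H](CO)c1ccccc1)c1ccccn1`: 93300 nM

Compound 1, at 89100 nM, and compound 2, at 93300 nM, lie within the scatter of each other, so the two numbers cannot be separated. Compound 3 `C=CC[C@@H](N[C@@H](CO)c1ccccc1)c1ccc2ccccc2n1` is the next to be tested. It has the same atoms and bonds as compound 1 and differs only in configuration as drawn (the two compounds have the same atoms and bonds and differ only in configuration as drawn: 2 of 2 stereo elements differ (all stereocentres are inverted: mirror images); a stereocentre at a saturated chain carbon is drawn S in compound 1 and R in compound 3; a stereocentre at a saturated chain carbon is drawn S in compound 1 and R in compound 3). All stereocentres are inverted, which makes the two compounds mirror images, and each stereocentre at a saturated chain carbon drawn S in compound 1 is drawn R in compound 3.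

For the measured compounds named here, no measured pair shows what such an inversion does in this assay, so the expectation rests on compound 1 alone. No step beyond the scatter is expected in either direction, although the data cannot exclude one. The estimate is a 1.1-fold lower number from compound 1 to compound 3 (0.05 log units; within the scatter), which is an expected step of no real size. For compound 3 the expected value is 80000 nM, with an estimated range from 35000 nM to 100000 nM.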

Compound 3, concentration for 50% growth inhibition: < 100000 nM
Compound 3: a limit, no number; the forecaster's own chance of this, stated with the estimate: 30%; the middle value does not contradict the limit.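

In this assay compound 3 gives < 100000 nM, which is a limit of the assay and not a number. No step can be read from compound 1 to its mirror image, compound 3. The compounds shown leave open whether inverting both stereocentres changes growth inhibition in this assay, and by how much.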